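A few compounds are considered here, and "the series" means these few. Any claim that something is new, unique, unknown or untested is made for them only; others in the source may bear on it.

In an ADME assay (liver) for metabolic stability, with Liver microsome (Rattus norvegicus) as the target, using microsomes, with a stated time of 30 min, tested at 1 uM (on this read-out higher numbers stand for fast clearance and lower numbers for slow clearance), compound 1 (`O=C(CCSc1nc2c(c(=O)[nH]1)CCCC2)N[C@H]1CC[C@H](c2nnc(-c3ccccc3)o2)CC1`) gives 60 mL.min-1.g-1, while compound 2 (`O=C(CCc1nc2ncccc2c(=O)[nH]1)N[C@H]1CC[C@H](c2nnc(-c3ccccc3)o2)CC1`) gives 24 mL.min-1.g-1. Compound 2 therefore holds the lower of the two numbers, and the gap between them lies beyond the usual scatter of repeat measurements. Compound 3 (`O=C(CCSc1nccc(=O)[nH]1)N[C@H]1CC[C@H](c2nnc(-c3ccccc3)o2)CC1`) departs from compound 2 by one swap: a group of 8 heavy atoms (4 carbon, 2 nitrogen, 1 oxygen, 1 sulfur; one six-membered aromatic ring with 2 hetero atoms) in place of a group of 11 heavy atoms (7 carbon, 3 nitrogen, 1 oxygen; one six-membered aromatic ring with 1 hetero atom, one six-membered aromatic ring with 2 hetero atoms), on a saturated chain carbon, two bonds along the chain from a carbonyl carbon. The swap sits on a saturated chain carbon, two bonds along the chain from a carbonyl carbon. Going by the values given here, no measured pair isolates this change, so the guidance is thin. Among the compounds with values here, the entering group carries sulfur, and the only measured compound with sulfur is compound 1, at 60 mL.min-1.g-1, so a modest rise is expected in this assay. The expected step is a 1.5-fold higher number from compound 2 to compound 3 (0.18 log units; within the scatter), which would stay within the scatter. For compound 3 the estimated value is 36 mL.min-1.g-1, with a likely range of 15 mL.min-1.g-1 to 85 mL.min-1.g-1.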

Compound 3, intrinsic clearance in microsomes: < 14 mL.min-1.g-1
Compound 3: a limit, no number (the forecaster's own chance of this, stated with the estimate: 3%); at least 2.5-fold (0.41 log units) between middle value and limit.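

In this assay compound 3 gives < 14 mL.min-1.g-1, which is a limit of the assay and not a number. Taking away the six-membered non-aromatic ring of carbon only, on a sulfur, gives an at least 4.2-fold lower number from compound 1 to compound 3 (0.63 log units; beyond the scatter), so this pair shows that a chain sulfur does not by itself go with a high clearance number. The swap on the saturated chain carbon gives an at least 1.7-fold lower number from compound 2 to compound 3 (0.23 log units; that floor lies within the scatter), and since that floor lies within the scatter, this step alone does not establish a real difference, although the true step may be larger.

Going by these compounds, how far the true value of compound 3 lies under the limit remains open, and this swap changes the ring system and the sulfur at once, so their shares cannot be separated. On these data alone, whether an amine or a longer chain on that saturated chain carbon would keep clearance this low is also open.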